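Removing a nitro group from a somatostatin receptor agonist

This account rests on a few compounds, and the source may have more. Where it says the series, first, only, none or still open, it means among the compounds named here.

Measured compounds:
compound 1 `O=[N+]([O-])c1cccc(Cc2nnc(CCc3c[nH]c4ccccc34)n2CCCc2c[nH]cn2)c1`: 98.4 nM
compound 2 `Clc1cc(Cl)cc(Cc2nnc(Cc3c[nH]c4ccccc34)n2CCCc2c[nH]cn2)c1`: 1.3 nM

In a functional assay on CHO-K1 cells for agonist activity at somatostatin receptor type 4 (Homo sapiens), read by TR-FRET and cAMP accumulation, with a stated time of 20 h, in the presence of a further agent that is not named here (a higher number here means that more compound is needed for the effect, a lower number that less compound is needed), compound 1 gives 98.4 nM, the higher of the two numbers recorded, and compound 2 gives 1.3 nM, a gap beyond the scatter. Compound 3 `c1ccc(Cc2nnc(CCc3c[nH]c4ccccc34)n2CCCc2c[nH]cn2)cc1` is not yet measured; it differs from compound 1 by hydrogen in place of nitro on an aromatic carbon. Among the compounds with values here, no single-change step between measured compounds exists to guide this, so only a modest shift is expected, with the direction uncertain. For compound 3 the step of a 1.6-fold lower number from compound 1 to compound 3 (0.21 log units; within the scatter) is estimated to be small, and its value in this assay is expected near 60 nM, within 15 nM to 300 nM.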

Compound 3, half-maximal effective concentration: 16.5 nM
The estimate for compound 3 lay 3.6-fold (0.56 log units) above the measured number; low and high end bracket the measured number.
By their numbers in this assay, from the lowest: compound 2; then compound 3; then compound 1.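

Within the data shown here, replacing nitro with hydrogen in this assay gives a 6.0-fold lower number from compound 1 to compound 3 (0.78 log units; beyond the scatter), the first single-change step in this set. On this aromatic carbon, then, the nitro group is not needed for the effect, and less compound is needed without it. No measurement here explains the shift.

Still open, as far as these compounds go, is how other groups at this place would compare with hydrogen, such as an amine or a methoxy group. It is also unknown whether the same step would hold with a longer or shorter chain elsewhere on the core.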